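Methyl for trifluoromethyl on a scaffold silent in cytotoxicity

This account rests on a few compounds, and the source may have more. Where it says the series, first, only, none or still open, it means among the compounds named here.

Three compounds sharing one core were tested in a functional assay on HepG2 cells (Homo sapiens) for cytotoxicity, read by luminescence, with a stated time of 72 h; on this read-out lower numbers stand for an effect already at smaller amounts and higher numbers for an effect only at larger amounts of compound. Compound 1 `CN(Cc1ccccc1)C(=O)c1sc(-c2ccc(S(C)(=O)=O)c([N+](=O)[O-])c2)nc1C(F)(F)F` gives only a limit, > 27000 nM. Compound 2 `CC1(C)CC2CC(C)(CN2C(=O)c2sc(-c3ccc(S(C)(=O)=O)c([N+](=O)[O-])c3)nc2C(F)(F)F)C1` likewise sits at a limit, > 27000 nM. Compound 3 `CC1CCN(C(=O)c2sc(-c3ccc(S(C)(=O)=O)c([N+](=O)[O-])c3)nc2C(F)(F)F)CC1` also reaches only a limit, > 27000 nM. Because all three rest at the limit of > 27000 nM in this assay, at which 3 of the 3 values shown sit, the steps among them, such as a step that the two limits leave unreadable from compound 1 to compound 2 and a step that the two limits leave unreadable from compound 2 to compound 3, cannot be sized. Compound 4 `Cc1nc(-c2ccc(S(C)(=O)=O)c([N+](=O)[O-])c2)sc1C(=O)N1CC2(C)CC1CC(C)(C)C2` is reached from compound 2 through (methyl in place of trifluoromethyl on an aromatic carbon). Within the data shown here, no measured step touches this part of the shared core, so none bears on it, and nothing points to a change in this assay beyond the scatter. Compound 4 is therefore expected to remain at the limit, estimated near 30000 nM within 10000 nM to 100000 nM. The step this estimate means, a step that the limit leaves unreadable from compound 2 to compound 4, is expected to be none beyond the scatter.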

Compound 4, half-maximal effective concentration: > 27000 nM
Compound 4: no number, only a limit; the forecaster's own chance of this, stated with the estimate: 80%; the middle value does not contradict the limit.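

Among these compounds, no step from compound 2 to compound 4 can be read, since both compounds give only a limit: the limit of > 27000 nM in this assay, at which 4 of the 4 values shown sit.

From the compounds shown here alone, whether methyl in place of trifluoromethyl on an aromatic carbon changes the read-out in this assay at all stays open, as does any ranking among the four compounds.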